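This account rests on a few compounds, and the source may have more. Where it says the series, first, only, none or still open, it means among the compounds named here.

Measured in a physicochemical assay for solubility, at pH 7.4; a higher number here means a more soluble compound, a lower number a less soluble compound
- compound 1 `C[C@H]1[C@H](N)CN1c1cc2c(cc1F)c(=O)c(C(=O)O)cn2C1CC1` gives 9.9 ug/mL
- compound 2 `C[C@H]1N(c2c(F)cc3c(=O)c(C(=O)O)cn(C4CC4)c3c2F)C[C@]1(C)N` gives 3.3 ug/mL

Compound 2 stands lowest of the two at 3.3 ug/mL in this set, and compound 1 at 9.9 ug/mL lies above it by more than the usual scatter.

Compound 3 `C[C@H]1N(c2cc3c(cc2F)c(=O)c(C(=O)O)cn3C2CC2)C[C@]1(C)N` awaits measurement. It has hydrogen in place of fluoro on an aromatic carbon of compound 2 (hydrogen in place of fluoro on an aromatic carbon), and the rest of the structure stays the same.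

Among the compounds with values here, no two measured compounds differ in one place alone, so no measured step gives the size of this change. A modest upward step in this assay is expected, one that may not clear the scatter by much. Within the data shown here, this expectation is weak and rests only on the two values so far, since compound 2 at 3.3 ug/mL is the lower one and compound 1 at 9.9 ug/mL is the only higher one. The expected change is a 1.7-fold higher number from compound 2 to compound 3 (0.22 log units; within the scatter) in this estimate. For compound 3 the estimated value is 5.5 ug/mL with an expected range of 2.5 ug/mL to 13 ug/mL for a measurement still to come.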

Compound 3, solubility: 1.3 ug/mL
The estimate for compound 3 lay 4.2-fold (0.63 log units) above the measured number; the whole stated range lies above it.
By their numbers in this assay, from the lowest: compound 3; then compound 2; then compound 1.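

In this assay, within the data shown here, the first reading of a single change at this position shows a 2.5-fold lower number from compound 2 to compound 3 (0.40 log units; beyond the scatter) when hydrogen takes the place of fluoro on an aromatic carbon, so this change moves the number down rather than up. With hydrogen on that carbon in both compounds, a group of 7 heavy atoms in place of a group of 6 heavy atoms gives a 7.6-fold lower number from compound 1 to compound 3 (0.88 log units; beyond the scatter), a second step that can now be read separately. Compound 3 is therefore the lowest of the three, and the route from compound 2 through compound 3 to compound 1 runs first down and then up, which the direct comparison of compound 2 with compound 1, two compounds differing in more than one place, could not show.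

Going by these compounds, whether chloro or methoxy on the same aromatic carbon would read closer to fluoro or to hydrogen remains open, as does the size of the fluoro-to-hydrogen step when the group of 6 heavy atoms is present. No accompanying measurement bears on the reason for either step.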